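The source may hold more compounds than are shown below. What is called first, only, known or untested is meant among the compounds shown, and "the series" means these compounds.

In an ADME assay on Vero cells (Chlorocebus sabaeus) for cytotoxicity, read by MTT assay (a lower number here means a stronger inhibitor, a higher number a weaker inhibitor), two esters of the series have been measured so far. Compound 1 `CCC(CC)C(=O)OCC(C)(C)CC1=C(O)C(=O)c2ccccc2C1=O` gives 104000 nM, and compound 2 `CCCCCCC(C)C(=O)OCC(C)(C)CC1=C(O)C(=O)c2ccccc2C1=O` gives 450 nM, the lower of the two numbers. Among the compounds with values here, the only measured step, a 230-fold lower number from compound 1 to compound 2 (2.36 log units; beyond the scatter), is large and beyond the scatter; it puts 1-methylheptyl in place of pentan-3-yl on a carbonyl carbon. Compound 3 `CCCCCCCCC(=O)OCC(C)(C)CC1=C(O)C(=O)c2ccccc2C1=O` has octyl in place of 1-methylheptyl on a carbonyl carbon. Here the same atoms are only joined differently, while the measured step changed the group's atoms, so a 230-fold lower number from compound 1 to compound 2 (2.36 log units; beyond the scatter) is a weak guide to the size of this change. No step beyond the scatter is expected in this assay, and no direction can be favoured. The expected step is a 1.1-fold higher number from compound 2 to compound 3 (0.05 log units; within the scatter). For compound 3 the estimated value is 500 nM, with an expected range of 150 nM to 2500 nM.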

Compound 3, half-maximal inhibitory concentration: 150000 nM
Compound 3: middle estimate off by 300-fold (2.48 log units), on the low side; the whole stated range lies below it.
By their numbers in this assay, from the lowest: compound 2; then compounds 1 and 3 (each within the scatter of the next).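

In this assay the same atoms joined differently shift the number sharply (a 330-fold higher number from compound 2 to compound 3 (2.52 log units; beyond the scatter)), so at this place, on a carbonyl carbon whose other neighbours are oxygen next to a carbonyl group, the arrangement of the chain matters and not only its atoms. Chain size alone does not set the number: octyl in place of pentan-3-yl leaves the two compounds within the scatter (a 1.4-fold higher number from compound 1 to compound 3 (0.16 log units; within the scatter)), and only compound 2 stands apart. Nothing available accounts for this difference between the isomers.

Branching alone does not give the low number, since pentan-3-yl is also branched and compound 1 stays high, so the requirement may combine branch and chain length. From the compounds shown here alone, whether 1-methylhexyl or 1-methylnonyl would keep the low number of compound 2 remains open.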